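The source may hold more compounds than are shown below. What is called first, only, known or untested is meant among the compounds shown, and "the series" means these compounds.

Measured so far in an ADME assay on LL24 cells (Homo sapiens) for inhibition, read by MTT assay, with a stated time of 24 h (a higher number here means a weaker inhibitor, a lower number a stronger inhibitor), each result being a limit and not a number:

- Compound 1 `CC(C)(C)c1ccc(C(=O)N/N=C/c2ccc([N+](=O)[O-])o2)cc1`: > 200000 nM (a limit)
- Compound 2 `O=C(N/N=C/c1ccc([N+](=O)[O-])o1)C1CCCCC1`: > 200000 nM (a limit)
- Compound 3 `CC(C)(C)OC(=O)N/N=C/c1ccc([N+](=O)[O-])o1`: > 200000 nM (a limit)

Compound 3 therefore has no exact place on the scale. Its result is only a limit, and the results for compound 1 and compound 2 are limits of the same kind, so no order can be drawn among the three.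

Compound 4 `CCCCCC(=O)N/N=C/c1ccc([N+](=O)[O-])o1` has not yet been measured. It carries pentyl in place of tert-butoxy on a carbonyl carbon. Among the compounds with values here, only one measured step bears directly on this place, a step that the two limits leave unreadable from compound 2 to compound 3, and it offers no size to carry over. The broader evidence is the limit of > 200000 nM in this assay, at which 3 of the 3 values shown sit. With every result so far sitting at that limit, the data give no reason to expect a step beyond the usual scatter in this assay, in either direction. The expected change is a number no higher from compound 3 to compound 4 (the limit leaves the size open), and it is most likely that the assay will again report only a limit. For compound 4 the estimated value is 200000 nM, with an expected range of 80000 nM to 400000 nM.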

Compound 4, half-maximal inhibitory concentration: 99000 nM
For compound 4 the middle estimate is 2.0-fold (0.31 log units) above the measured one; low and high end bracket the measured number.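

In this assay compound 4 is the first compound shown to give a number and not a limit, 99000 nM, so a change at this place on the carbonyl carbon can yield a measurable result. Pentyl in place of tert-butoxy gives an at least 2.0-fold lower number from compound 3 to compound 4 (0.30 log units; that floor lies within the scatter), and pentyl in place of cyclohexyl gives an at least 2.0-fold lower number from compound 2 to compound 4 (0.30 log units; that floor lies within the scatter); each of these is only a floor, set by a limit on one side, so the real step may be larger, but neither floor alone goes beyond the usual scatter. The limit also remains the most common result in the set: the limit of > 200000 nM in this assay, at which 3 of the 4 values shown sit.

Steps between two compounds that both stand at the limit cannot be read, so the groups in those compounds cannot be ranked against one another. The compounds shown leave open whether a longer chain than pentyl, or a chain ending in an amine or a carboxylic acid, would bring the number in this assay lower still, and so whether the result for compound 4 marks the start of a trend or stands alone.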